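The source may report more compounds than this note shows. Statements on the series, on what has been measured and on what is new or still open speak of the compounds shown alone.

Measured in an assay on microsomes from intestine for inhibition of acyl-CoA:cholesterol acyltransferase (Oryctolagus cuniculus); on this read-out lower numbers stand for stronger inhibition and higher numbers for weaker inhibition:
compound 1, `CCCCCC(C)OC(=O)NC(=O)Nc1c(C(C)C)cccc1C(C)C`: 1060 nM
compound 2, `CCCCCCCC(C)OC(=O)NC(=O)Nc1c(C(C)C)cccc1C(C)C`: 390 nM
compound 3, `CCCCCCCCOC(=O)NC(=O)Oc1c(C(C)C)cccc1C(C)C`: 250 nM

Compound 2 stands apart from compound 1 by ethyl in place of hydrogen on a saturated chain carbon, six bonds along the chain from an oxygen next to a carbonyl group. This step gave a 2.7-fold lower number from compound 1 to compound 2 (0.43 log units; beyond the scatter). Compound 3 has the lowest of the three numbers in this assay; against compound 2 it lies within the scatter, against compound 1 beyond it. The core of compound 3 differs from that of compound 1, and the difference between the two cores is not broken down here.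

Compound 4, `CCCCCCCCCCOC(=O)NC(=O)Oc1c(C(C)C)cccc1C(C)C`, is not yet measured. It stands apart from compound 3 by ethyl in place of hydrogen on a saturated chain carbon, eight bonds along the chain from an oxygen next to a carbonyl group. This is the same kind of change as from compound 1 to compound 2, not the same: there the place was six bonds along the chain from an oxygen next to a carbonyl group, here it is eight bonds along the chain from an oxygen next to a carbonyl group. Among the compounds with values here, only one such step is measured, so the expectation rests on it alone. A step of about a 1.5-fold lower number from compound 3 to compound 4 (0.17 log units; within the scatter) is expected from compound 3 to compound 4. This is taken somewhat smaller than a 2.7-fold lower number from compound 1 to compound 2 (0.43 log units; beyond the scatter) because compound 3 already gives 250 nM. For compound 4 the estimate in this assay is 170 nM, expected between 80 nM and 400 nM.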

Compound 4, half-maximal inhibitory concentration: 74 nM
Compound 4: the middle estimate sits 2.3-fold (0.36 log units) above what was measured; measured number below the stated range.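

The new step in this assay is a 3.4-fold lower number from compound 3 to compound 4 (0.53 log units; beyond the scatter), and it runs the same way as the earlier one, a 2.7-fold lower number from compound 1 to compound 2 (0.43 log units; beyond the scatter). Ethyl in place of hydrogen on the saturated chain carries over between the core of compound 1 and the core of compound 3 with no difference in size that can be told apart: the same change on two cores in this assay, a 2.7-fold lower number (0.43 log units; beyond the scatter) from compound 1 to compound 2 and a 3.4-fold lower number (0.53 log units; beyond the scatter) from compound 3 to compound 4, 1.2-fold (0.09 log units) apart, within the scatter of two such steps

This rests on two pairs alone, with the change at a different place along the chain in each, so it supports carrying the change between these two cores but gives no rule for other cores and no explanation of why the number falls.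

Still open, going by these compounds, is whether a longer chain than that of compound 4 goes on lowering the number in this assay or reverses the direction of the step. Also open, on these data alone, is how a chain ending in an amine or a carboxylic acid would behave on either core.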